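A few compounds are considered here, and "the series" means these few. Any claim that something is new, unique, unknown or untested is made for them only; others in the source may bear on it.

Working notes on the series, read in a functional assay on NCI-H460 cells (Homo sapiens) for cytotoxicity, read by sulforhodamine B assay; on this read-out higher numbers stand for lower toxicity in this test and lower numbers for higher toxicity in this test. Compound 1 `CC1=CC[C@@H]([C@@](C)(O)CCCC(C)(C)NC=S)CC1` gives > 100000 nM, a limit of the assay and not a number. Compound 2 `CC1=CC[C@@H]([C@@](C)(O)CCCC(C)(C)NC(=S)N/N=C\c2ccc(O)cc2)CC1` gives > 100000 nM, likewise only a limit. Compound 2 thus has no number of its own, and the measured picture so far is the limit of > 100000 nM in this assay, at which 2 of the 2 values shown sit. Compound 3 `CC1=CC[C@@H]([C@@](C)(O)CCCC(C)(C)NC(=S)N/N=C\c2ccc(Cl)cc2)CC1` carries 4-chlorophenyl where compound 2 carries 4-hydroxyphenyl: chloro in place of hydroxy on an aromatic carbon. The change is chloro in place of hydroxy on an aromatic carbon, para to a large group. No measured step sizes this change, so the expectation rests only on the limit of compound 2, > 100000 nM. Compound 3 is expected to stay close to that limit, with any move toward higher toxicity in this test being modest. The expected change is an at least 1.2-fold lower number from compound 2 to compound 3 (0.09 log units; that floor lies within the scatter). For compound 3 the estimated value is 80000 nM, with an expected range of 25000 nM to 150000 nM.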

Compound 3, concentration lethal to 50% of the cells: > 100000 nM
Compound 3: only a limit was reported; the forecaster's own chance of this, stated with the estimate: 60%; middle value at least 1.2-fold (0.09 log units) away from the limit.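

No step can be read from compound 2 to compound 3 in this assay, as both results are limits and not numbers: the limit of > 100000 nM in this assay, at which 3 of the 3 values shown sit. The compounds shown leave open whether any member of the series gives a measurable number in this assay.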